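The source may report more compounds than this note shows. Statements on the series, on what has been measured and on what is new or still open speak of the compounds shown alone.

Working notes on the series.

Compound 1 `CC(C)=CCC/C(C)=C/CC/C(C)=C/CC[C@@H]1[C@@]2(C)CC/C(=N\OCc3cn(-c4c(Cl)cc([N+](=O)[O-])cc4Cl)nn3)C(C)(C)[C@@H]2CC[C@@]1(C)O` and compound 2 `COc1cc(OC)c(-n2cc(CO/N=C3\CC[C@]4(C)[C@@H](CC/C=C(\C)CC/C=C(\C)CCC=C(C)C)[C@](C)(O)CC[C@H]4C3(C)C)nn2)c(OC)c1` share one core; compound 3 `CC(C)=CCC/C(C)=C/CC/C(C)=C/CC[C@@H]1[C@@]2(C)C/C(=C\c3ccc(OCc4cn(-c5c(Cl)cc([N+](=O)[O-])cc5Cl)nn4)cc3)C(=O)C(C)(C)[C@@H]2CC[C@@]1(C)O` and compound 4 `COc1cc(OC)c(-n2cc(COc3ccc(/C=C4\C[C@]5(C)[C@@H](CC/C=C(\C)CC/C=C(\C)CCC=C(C)C)[C@](C)(O)CC[C@H]5C(C)(C)C4=O)cc3)nn2)c(OC)c1` share another. The difference between the two cores is not broken down here. In a functional assay on DU-145 cells (Homo sapiens) for cytotoxicity, read by MTT assay, with a stated time of 48 h (a lower number here means a stronger inhibitor, a higher number a weaker inhibitor), compound 1 gives 16400 nM. Compound 2 carries 2,4,6-trimethoxyphenyl in place of 2,6-dichloro-4-nitrophenyl on an aromatic nitrogen, and in this assay compound 2 gives 11100 nM. The step is a 1.5-fold lower number from compound 1 to compound 2 (0.17 log units; within the scatter). In this assay compound 3 gives 20900 nM; against compound 1 and compound 2 the three numbers sit close together, with no ordering to be read from them.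

Compound 4 carries the same change on the core of compound 3, namely (2,4,6-trimethoxyphenyl in place of 2,6-dichloro-4-nitrophenyl on an aromatic nitrogen), at the same place as in the pair from compound 1 to compound 2. Within the data shown here, for compound 4 the expected step in this assay is a 1.5-fold lower number from compound 3 to compound 4 (0.17 log units; within the scatter), set beside the step already seen, and resting on the pair from compound 1 to compound 2 with its a 1.5-fold lower number from compound 1 to compound 2 (0.17 log units; within the scatter), which is the only reading of this change available. For compound 4 in this assay the estimate is 14000 nM, expected to fall between 7000 nM and 28000 nM.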

Compound 4, half-maximal inhibitory concentration: 12000 nM
Compound 4: middle estimate off by 1.2-fold (0.07 log units), on the high side; the range from low to high includes it.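

Carrying the change to the core of compound 3 gives a 1.7-fold lower number from compound 3 to compound 4 (0.24 log units; within the scatter) in this assay, and this agrees with the step on the core of compound 1: the same change on two cores in this assay, a 1.5-fold lower number (0.17 log units; within the scatter) from compound 1 to compound 2 and a 1.7-fold lower number (0.24 log units; within the scatter) from compound 3 to compound 4, 1.2-fold (0.07 log units) apart, within the scatter of two such steps.

On these two cores, then, 2,4,6-trimethoxyphenyl in place of 2,6-dichloro-4-nitrophenyl behaves alike, but what carries over is a step that stays within the scatter each time, not a demonstrated gain in potency. Two pairs sharing one exchange of groups do not show that the agreement would hold on any further core, and they say nothing about where a real effect of this position would begin.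

The compounds shown leave open whether a group of another kind on that aromatic nitrogen, such as an unsubstituted phenyl or a chain ending in an amine or a carboxylic acid, would move the number beyond the scatter. Also open, from the compounds shown here alone, is whether a shorter chain in place of the long unsaturated chain would shift the values on either core.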